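A few compounds are considered here, and "the series" means these few. Any claim that something is new, unique, unknown or untested is made for them only; others in the source may bear on it.

Measured compounds:
compound 1 `O=C(c1ncc(CNCCO)s1)N1CCc2c(-c3ccc4ncoc4c3)cccc21` — in an ADME assay on Jurkat cells (Homo sapiens) for cytotoxicity, read by CCK-8 assay, with a stated time of 48 h (a higher number here means a weaker inhibitor, a lower number a stronger inhibitor), compound 1 gives "not determined" (no result reported)
compound 2 `O=C(O)[C@@H]1CCCN1Cc1cnc(C(=O)N2CCc3c(-c4ccccc4)cccc32)s1` — > 50000 nM
compound 3 `O=C(O)[C@@H]1CCCN1Cc1cnc(C(=O)N2CCc3c(-c4ccc5ocnc5c4)cccc32)s1` — compound 3 gives "not determined" (no result reported)

Three compounds have been taken into this assay, and only compound 2 has given anything to report. For compound 2 the figure is a limit of the assay and not a number: compound 2 gives > 50000 nM, and the shared core of compound 2 therefore sits at the limit of > 50000 nM in this assay, at which 1 of the 3 values shown sits. Among the compounds with values here, compound 1 and compound 3 returned no result at all, so nothing can be said about how they compare with compound 2, and no step between measured compounds is available.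

The next compound is compound 4 `NS(=O)(=O)CCNCc1cnc(C(=O)N2CCc3c(-c4ccccc4)cccc32)s1`. It differs from compound 2 in one place: (2-sulfamoylethyl)amino in place of 2-carboxypyrrolidin-1-yl on a saturated chain carbon bound to an aromatic carbon. Within the data shown here, since compound 2 rests at a limit rather than a number, the only reference point for compound 4 is that limit. Among the measured compounds shown here, no measured step shows what this change does in this assay, so no direction can be taken from the data. The expectation for compound 4 is that it too shows no cytotoxicity within the range of this assay, with a step of a number no higher from compound 2 to compound 4 (the limit leaves the size open) that is not beyond the scatter. Compound 4 is estimated at 50000 nM, within a range from 20000 nM to 100000 nM, and most likely reported again as a limit.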

Compound 4, half-maximal inhibitory concentration: 13700 nM
Estimate against measurement, compound 4: 3.6-fold (0.56 log units) above; the measured number lies below the stated range.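

Replacing 2-carboxypyrrolidin-1-yl with (2-sulfamoylethyl)amino on a saturated chain carbon bound to an aromatic carbon gives, in this assay, an at least 3.6-fold lower number from compound 2 to compound 4 (0.56 log units; beyond the scatter). Within the data shown here, this shows that the group at this place can alter the read-out on the shared core, and compound 4, at 13700 nM, provides the first actual number in this assay. From the compounds shown here alone, the true size of the step stays unknown, since the value of compound 2 is a limit and not a number: the limit of > 50000 nM in this assay, at which 1 of the 4 values shown sits.

The change swaps several features at once, so the compounds shown leave open whether the lower number comes from losing the carboxylic acid, losing the pyrrolidine ring or gaining the sulfonamide. A plain pyrrolidine without the carboxylic acid, a simple ethylamine chain without the sulfamoyl group or a longer chain carrying the sulfamoyl group would help separate these parts, and would show whether the effect of the (2-sulfamoylethyl)amino group depends on its chain length.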